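A Nitro Group Enters the Core of Compound 1

The source may report more compounds than this note shows. Statements on the series, on what has been measured and on what is new or still open speak of the compounds shown alone.

Compound 1 `O=c1oc2ccccc2n1Cc1ccc(Cl)cc1` and compound 2 `O=c1oc2ccc(F)cc2n1Cc1cccc(F)c1` were both tested in an assay on HeLa cells for inhibition of Indoleamine 2,3-dioxygenase 1 (Homo sapiens), with a stated time of 24 h; a lower number here means a stronger inhibitor, a higher number a weaker inhibitor. In this assay compound 1 gives 35000 nM, the highest of the two numbers shown. In this assay compound 2 gives 28500 nM, and the two values lie within the usual scatter of each other, so neither compound can be called the stronger inhibitor on this evidence.

Compound 3 `O=c1oc2ccc([N+](=O)[O-])cc2n1Cc1ccc(Cl)cc1` has not been measured yet. It differs from compound 1 in one place: nitro in place of hydrogen on an aromatic carbon. The new group sits on an aromatic carbon of a six-membered aromatic ring of carbon only, part of a fused or bridged system of two rings, meta to a fused ring and para to a fused ring. For the measured compounds named here, no pair of measured compounds shows this exact change, so nothing measured here tells how large its effect is. The step from compound 1 to compound 3 is expected to be modest, a 1.8-fold lower number from compound 1 to compound 3 (0.24 log units; within the scatter), toward a lower number but close to the scatter. Compound 3 is therefore estimated at 20000 nM, within a range from 6000 nM to 60000 nM.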

Compound 3, half-maximal inhibitory concentration: 99400 nM
The estimate for compound 3 lay 5.0-fold (0.70 log units) below the measured number; measured number outside the range, above it.
By their numbers in this assay, from the lowest: compounds 2 and 1 (each within the scatter of the next); then compound 3.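

In this assay, nitro in place of hydrogen on this aromatic carbon gives a 2.8-fold higher number from compound 1 to compound 3 (0.45 log units; beyond the scatter) and so makes for a weaker inhibitor, a change that is modest in size but beyond the scatter. For the compounds shown here, this is the first step that isolates a single change, and it shows that this place on the six-membered aromatic ring of carbon only is not indifferent to what is attached there, since adding nitro moved the number in the unfavourable direction. Nothing available explains why adding nitro at this place weakens inhibition.

The compounds shown give only this one single-place change at this position, so they cannot tell whether the loss belongs to nitro alone or would also follow other groups on the same carbon, such as an amine, a methoxy group or a carboxylic acid. Nor can they tell whether nitro on this carbon would have the same effect if the rest of the molecule were changed, or what the same group would do elsewhere on the ring.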